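The source may report more compounds than this note shows. Statements on the series, on what has been measured and on what is new or still open speak of the compounds shown alone.

Series sharing the core of compound 1 `C=CC1=C(C(=O)NCc2ccc(Cl)cc2)C(c2ccc(F)cc2)OC1`, an amide bearing 4-chlorobenzyl on the amide-type nitrogen, tested in a functional assay on A549 cells (Homo sapiens) for cytotoxicity, read by MTT assay, with a stated time of 24 h; a higher number here means a weaker inhibitor, a lower number a stronger inhibitor. In this assay compound 1 gives > 100000 nM, which is a limit of the assay and not a number. Compound 2 `C=CC1=C(C(=O)Nc2ccccc2OC)C(c2ccc(F)cc2)OC1` carries 2-methoxyphenyl on the amide-type nitrogen instead. In this assay compound 2 gives > 100000 nM, again a limit rather than a number. Compound 3 `C=CC1=C(C(=O)NCC(C)C)C(c2ccc(F)cc2)OC1` carries isobutyl on that nitrogen. In this assay compound 3 gives > 100000 nM, also only a limit. The steps a step that the two limits leave unreadable from compound 1 to compound 2, a step that the two limits leave unreadable from compound 1 to compound 3 and a step that the two limits leave unreadable from compound 2 to compound 3 stay unreadable because of the limit of > 100000 nM in this assay, at which 3 of the 3 values shown sit. Compound 4 `C=CC1=C(C(=O)Nc2ccccc2OC)C(c2ccc(Cl)c(Cl)c2)OC1` is not yet measured and differs from compound 2 by 3,4-dichlorophenyl in place of 4-fluorophenyl on a saturated ring carbon. Among the compounds with values here, none of the measured steps touches this saturated ring carbon, and every measured value rests at the same limit, so no direction of change can be read from them. Compound 4 is therefore expected to give 100000 nM in this assay, with an expected range of 30000 nM to 300000 nM. This estimate means an expected step of a number no higher from compound 2 to compound 4 (the limit leaves the size open).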

Compound 4, half-maximal inhibitory concentration: > 100000 nM
Compound 4: no number, only a limit; the forecaster's own chance of this, stated with the estimate: 75%; the middle value sits exactly at the limit.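

Compound 4 gives > 100000 nM, which is a limit and not a number, so the step from compound 2 to compound 4 cannot be read: the limit of > 100000 nM in this assay, at which 4 of the 4 values shown sit.

The compounds shown leave open whether changing the group on the amide-type nitrogen or on the saturated ring carbon has any effect in this assay.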